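This account rests on a few compounds, and the source may have more. Where it says the series, first, only, none or still open, it means among the compounds named here.

Notes on the core of compound 1 `CCCSc1nc(N)nc2c1ncn2/C=C1/CC1(CO)CO`. For the measured compounds named here, in an ADME assay on CCRF-HSB-2 cells (Homo sapiens) for cytotoxicity, with a stated time of 7 days (on this read-out lower numbers stand for higher toxicity in this test and higher numbers for lower toxicity in this test), compound 1 gives 98000 nM, which is the only plain number so far. Compound 2 `CCCCCCOc1nc(N)nc2c1ncn2/C=C1/CC1(CO)CO` carries hexyloxy in place of propylsulfanyl on an aromatic carbon. In this assay compound 2 is reported as a limit, > 20000 nM, not as a number. The step that the limit leaves unreadable from compound 1 to compound 2 therefore cannot be sized, one of its two ends being (the limit of > 20000 nM in this assay, at which 1 of the 2 values shown sits). Compound 1 thus stands as the single measured point, with nothing to order it against.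

Compound 3 `CCCCNc1nc(N)nc2c1ncn2/C=C1/CC1(CO)CO` is still to be measured. Relative to compound 1 the change is butylamino in place of propylsulfanyl on an aromatic carbon. Going by the values given here, no measured step bears on such an exchange: the one step in hand is unreadable, so no direction is indicated. In this assay compound 3 is expected close to compound 1, the step of a 1.0-fold higher number from compound 1 to compound 3 (0.01 log units; within the scatter) staying within the scatter. Compound 3 is estimated at 100000 nM, with a range from 30000 nM to 300000 nM, and a fair chance that only a limit is reported.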

Compound 3, half-maximal cytotoxic concentration: > 20000 nM
Compound 3 ended at the assay's limit (the forecaster's own chance of this, stated with the estimate: 50%); the middle value does not contradict the limit.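

The steps linking compound 3 with compound 1 and compound 2 cannot be read, so the comparison gains no size or direction, and the series now rests largely on one limit: the limit of > 20000 nM in this assay, at which 2 of the 3 values shown sit.

The compounds shown leave open how propylsulfanyl, hexyloxy and butylamino on the shared core rank against one another in this assay.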